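Piperazine substituent changes and cytotoxicity in a leukaemia line

The source may report more compounds than this note shows. Statements on the series, on what has been measured and on what is new or still open speak of the compounds shown alone.

Compound 1 `COc1cc(Cc2cnc(/N=C3\C(=O)N(CN4CCN(Cc5ccccc5)CC4)c4ccc(Cl)cc43)nc2N)cc(OC)c1OC`: 94.7 ug/mL
Compound 2 `COc1cc(Cc2cnc(/N=C3\C(=O)N(CN4CCN(C)CC4)c4ccc(Cl)cc43)nc2N)cc(OC)c1OC`: 88 ug/mL

In an ADME assay on CCRF-CEM cells (Homo sapiens) for cytotoxicity, read by MTT assay, with a stated time of 5 days (on this read-out lower numbers stand for higher toxicity in this test and higher numbers for lower toxicity in this test), compound 2 gives the lower of the two numbers, and its nearest neighbour is compound 1, yet the step of a 1.1-fold lower number from compound 1 to compound 2 (0.03 log units; within the scatter) lies within the scatter. Compound 3 `COc1cc(Cc2cnc(/N=C3\C(=O)N(CN4CCN(c5ccc(Cl)cc5)CC4)c4ccc(Cl)cc43)nc2N)cc(OC)c1OC` carries 4-chlorophenyl in place of methyl on an amine nitrogen in a ring. Among the measured compounds shown here, the only measured step at this ring nitrogen, from compound 1 to compound 2, changed the number hardly at all, so no shift beyond the scatter is expected here either. The step of a 1.0-fold lower number from compound 2 to compound 3 (0.02 log units; within the scatter) is the estimated outcome. Compound 3 is expected to give 85 ug/mL, between 45 ug/mL and 160 ug/mL.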

Compound 3, half-maximal cytotoxic concentration: 40.1 ug/mL
Compound 3: middle estimate off by 2.1-fold (0.33 log units), on the high side; measured number outside the range, below it.
By their numbers in this assay, from the lowest: compound 3; then compounds 2 and 1 (each within the scatter of the next).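

In this assay the amine nitrogen in a ring proves able to move the number after all: 4-chlorophenyl there gives a 2.2-fold lower number from compound 2 to compound 3 (0.34 log units; beyond the scatter) and a 2.4-fold lower number from compound 1 to compound 3 (0.37 log units; beyond the scatter) and both steps lie beyond the scatter, whereas benzyl and methyl had stayed within it. A six-membered aromatic ring on this side of the molecule does not by itself decide the outcome, since benzyl carries one too. The compounds leave open whether the chlorine or the direct attachment of the ring to the nitrogen matters, which a plain phenyl or a 4-methoxyphenyl there would help to separate. Nothing shown gives a reason for the shift.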